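This account rests on a few compounds, and the source may have more. Where it says the series, first, only, none or still open, it means among the compounds named here.

Of the compounds shown here, three with one shared core have been tested in an ADME assay on NIH3T3 cells (Mus musculus) for cytotoxicity, read by MTT assay, with a stated time of 24 h; a lower number here means a stronger inhibitor, a higher number a weaker inhibitor. Compound 1 `Cc1ccc(-c2cs/c(=N/NC(=O)CSc3nnnn3C)n2-c2ccccc2)cc1` gives 243 ug/mL, compound 2 `COc1ccc(-c2cs/c(=N/NC(=O)CSc3nnnn3C)n2-c2ccccc2)cc1` gives 45 ug/mL, and compound 3 `Cn1cnnc1SCC(=O)N/N=c1/scc(-c2ccccc2)n1-c1ccccc1` gives 217 ug/mL. Within the data shown here, the only change measured between two of them, a 5.4-fold lower number from compound 1 to compound 2 (0.73 log units; beyond the scatter), sits on an aromatic carbon. Compound 3 stands second highest of the three numbers: its value is within the scatter of compound 1 and clearly apart from compound 2. Compound 4 `Cn1nnnc1SCC(=O)N/N=c1/scc(-c2ccccc2)n1-c1ccccc1` differs from compound 3 by 1-methyl-1H-tetrazol-5-yl in place of 4-methyl-4H-1,2,4-triazol-3-yl on a sulfur. Among the measured compounds shown here, no measured step touches this part of the molecule, so nothing here tells the size or direction of the effect. The step is therefore expected to stay within the scatter, a 1.0-fold lower number from compound 3 to compound 4 (0.01 log units; within the scatter). Compound 4 is expected to give about 210 ug/mL, with a range from 100 ug/mL to 440 ug/mL.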

Compound 4, half-maximal inhibitory concentration: 173 ug/mL
Compound 4: the middle estimate sits 1.2-fold (0.08 log units) above what was measured, within the range that was stated.
By their numbers in this assay, from the lowest: compound 2; then compounds 4, 3 and 1 (each within the scatter of the next).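

On the sulfur, in this assay, 1-methyl-1H-tetrazol-5-yl in place of 4-methyl-4H-1,2,4-triazol-3-yl gives a 1.3-fold lower number from compound 3 to compound 4 (0.10 log units; within the scatter) and so no readable change at this position. On the aromatic carbon, hydrogen in place of methyl gives a 1.4-fold lower number from compound 1 to compound 4 (0.15 log units; within the scatter) while hydrogen in place of methoxy gives a 3.8-fold higher number from compound 2 to compound 4 (0.58 log units; beyond the scatter) and so, of these two groups, only methoxy stands apart from hydrogen. Nothing available explains these steps. Still open, going by these compounds, is whether a carboxylic acid or an amine on the chain in place of the ring on the sulfur would shift the number, and whether methoxy has the same effect with 4-methyl-4H-1,2,4-triazol-3-yl on the sulfur.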